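A few compounds are considered here, and "the series" means these few. Any claim that something is new, unique, unknown or untested is made for them only; others in the source may bear on it.

Three compounds share one core and differ only in the group on a nitrogen on an aromatic ring. Compound 1 `CC(C)N(C)c1nc2ccc(NC(=O)CCc3ccc(C(F)(F)F)cc3)cc2[nH]1` carries an isopropyl there and gives 5.9 nM in an assay on CHO-K1 cells for displacement of a labelled ligand from melanin-concentrating hormone receptor 1 (Homo sapiens), read by scintillation counting; on this read-out higher numbers stand for weaker inhibition and lower numbers for stronger inhibition. Compound 2 `CC(=O)N1CCC(N(C)c2nc3ccc(NC(=O)CCc4ccc(C(F)(F)F)cc4)cc3[nH]2)C1` carries a 1-acetylpyrrolidin-3-yl and gives 30 nM. Compound 3 `CN(c1nc2ccc(NC(=O)CCc3ccc(C(F)(F)F)cc3)cc2[nH]1)C1CCOC1` carries an oxolan-3-yl and gives 27 nM, the second highest of the three numbers; it sits within the scatter of compound 2 and well apart from compound 1.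

Compound 4 `CN(C)c1nc2ccc(NC(=O)CCc3ccc(C(F)(F)F)cc3)cc2[nH]1` takes the next step: methyl in place of oxolan-3-yl on a nitrogen on an aromatic ring. For the measured compounds named here, no measured step swaps a ring for a methyl, so the nearest guide is the reverse of the step that brought the ring in, a 4.6-fold higher number from compound 1 to compound 3 (0.66 log units; beyond the scatter). The parallel step a 5.1-fold higher number from compound 1 to compound 2 (0.71 log units; beyond the scatter) points the same way, while a 1.1-fold lower number from compound 2 to compound 3 (0.05 log units; within the scatter) shows that the two rings behave alike. Taking the ring away is therefore expected to win back much of that difference, though methyl is smaller than isopropyl and has not been tested here, which leaves the expectation uncertain. The step to compound 4 is expected to be a 2.7-fold lower number from compound 3 to compound 4 (0.43 log units; beyond the scatter). Compound 4 is estimated at 10 nM, with a likely range from 4 nM to 30 nM.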

Compound 4, half-maximal inhibitory concentration: 12 nM
For compound 4 the middle estimate is 1.2-fold (0.08 log units) below the measured one; low and high end bracket the measured number.
By their numbers in this assay, from the lowest: compound 1; then compound 4; then compounds 3 and 2 (each within the scatter of the next).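

In this assay the two rings on this nitrogen can be given up with a gain: going down to a single methyl gives a 2.3-fold lower number from compound 3 to compound 4 (0.35 log units; beyond the scatter) and a 2.5-fold lower number from compound 2 to compound 4 (0.40 log units; beyond the scatter) and so neither oxolan-3-yl nor 1-acetylpyrrolidin-3-yl is needed for a low number here. Yet a smaller group does not simply mean a lower number, for putting methyl in place of isopropyl gives a 2.0-fold higher number from compound 1 to compound 4 (0.31 log units; beyond the scatter) and leaves methyl, the smallest group of the four, in the middle of the order, with isopropyl lowest and the two rings highest. Nothing measured here explains why these groups fall in this order.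

The compounds shown leave open how narrow the best range of groups on this nitrogen is, since ethyl, cyclopropyl and tert-butyl would each help to show whether the number keeps falling beyond isopropyl or turns back up. They also leave open whether the higher numbers of the two rings come with having a ring at all or with the oxygen and the acetylated nitrogen in them, which a plain cyclopentyl could help to separate.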